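Trifluorophenyl aniline replacing dimethoxyphenyl on a sulfonamide-bearing quinazoline-type core

The source may report more compounds than this note shows. Statements on the series, on what has been measured and on what is new or still open speak of the compounds shown alone.

Compound 1 `COc1cc2ncnc(Nc3ccc(Cl)c(C(F)(F)F)c3)c2cc1OCCCCC(=O)Nc1ccc(S(N)(=O)=O)cc1`: 3220 nM
Compound 2 `COc1ccc(Nc2ncnc3cc(OC)c(OCCCCC(=O)Nc4ccc(S(N)(=O)=O)cc4)cc23)cc1OC`: 9230 nM

In a functional assay on NCI-H1975 cells (Homo sapiens) for antiproliferative activity, read by MTT assay, with a stated time of 72 h (on this read-out lower numbers stand for stronger inhibition and higher numbers for weaker inhibition), compound 2 gives the highest of the two numbers; its nearest neighbour is compound 1, which lies a 2.9-fold higher number from compound 1 to compound 2 (0.46 log units; beyond the scatter) away. Compound 3 `COc1cc2ncnc(Nc3cc(F)c(F)c(F)c3)c2cc1OCCCCC(=O)Nc1ccc(S(N)(=O)=O)cc1` carries the change (3,4,5-trifluorophenyl in place of 3,4-dimethoxyphenyl on a nitrogen on an aromatic ring). Within the data shown here, only one measured step bears on it: the move from a halogen-bearing aryl to the dimethoxyphenyl, a 2.9-fold higher number from compound 1 to compound 2 (0.46 log units; beyond the scatter), a modest rise. Returning to a halogenated aryl is therefore expected to give a modest step back down, a 2.3-fold lower number from compound 2 to compound 3 (0.36 log units; beyond the scatter), in this assay. Compound 3 is estimated at 4000 nM, within 1500 nM to 12000 nM.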

Compound 3, half-maximal inhibitory concentration: 20000 nM
Compound 3: middle estimate off by 5.0-fold (0.70 log units), on the low side; the whole stated range lies below it.
By their numbers in this assay, from the lowest: compound 1; then compound 2; then compound 3.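

In this assay, a halogen-bearing aryl group on this nitrogen does not by itself give a lower number: 3,4,5-trifluorophenyl in place of 3,4-dimethoxyphenyl gives a 2.2-fold higher number from compound 2 to compound 3 (0.34 log units; beyond the scatter). Replacing 4-chloro-3-(trifluoromethyl)phenyl with the same group gives a 6.2-fold higher number from compound 1 to compound 3 (0.79 log units; beyond the scatter), so the two halogen-bearing groups fall on opposite sides of 3,4-dimethoxyphenyl. Nothing available accounts for this order.

The compounds shown leave open where an unsubstituted phenyl or a 3-chlorophenyl would fall at this position. They also leave open whether the same order would hold with a longer chain on the shared core.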